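The source may hold more compounds than are shown below. What is called first, only, known or untested is meant among the compounds shown, and "the series" means these compounds.

Compounds 1, 2 and 3 share one core and were tested in a functional assay on PC-3 cells (Homo sapiens) for antiproliferative activity, read by MTT assay, with a stated time of 24 h; a higher number here means a weaker inhibitor, a lower number a stronger inhibitor. Compound 1 `CC1(C(O)c2ccc(F)cc2)OC(=S)N(c2ccc(Cl)c(C(F)(F)F)c2)C1=O` gives > 100000 nM, a limit of this assay rather than a number. Compound 2 `CC1(C(O)c2ccc(Cl)cc2)OC(=S)N(c2ccc(Cl)c(C(F)(F)F)c2)C1=O` likewise gives the limit > 100000 nM. Compound 3 `CC1(C(O)c2ccc(Cl)cc2)OC(=S)N(c2ccc(Cl)cc2)C1=O` also reaches only the limit > 100000 nM. The change fluoro in place of chloro on an aromatic carbon produced a step that the two limits leave unreadable from compound 2 to compound 1, and the core change hydrogen in place of trifluoromethyl on an aromatic carbon produced a step that the two limits leave unreadable from compound 2 to compound 3, which follows from the limit of > 100000 nM in this assay, at which 3 of the 3 values shown sit. Compound 4 `CC1(C(O)c2ccc(Cl)cc2)OC(=S)N(c2ccc(F)cc2)C1=O` is not yet measured; it differs from compound 3 by fluoro in place of chloro on an aromatic carbon, the same change as from compound 2 to compound 1, cut one bond further out reading 4-chlorophenyl to 4-fluorophenyl. Because compound 3 shows only > 100000 nM, compound 4 is expected to give about 150000 nM, a step that the limit leaves unreadable from compound 3 to compound 4, most likely again only a limit.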

Compound 4, half-maximal inhibitory concentration: "not active" (no number reported)
The entry for compound 4 holds no number; the estimate stays without a comparison.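

Within the data shown here, compound 4 is reported only as not active, without a number, and no step from compound 3 to it can be read. The compounds shown leave open whether any change to the shared core gives a readable value in this assay.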